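The source may report more compounds than this note shows. Statements on the series, on what has been measured and on what is new or still open speak of the compounds shown alone.

In a functional assay on RS4-11 cells (Homo sapiens) for inhibition, read by CCK-8 assay, with a stated time of 48 h, tested at 20 uM (a higher number here means more inhibition of growth at the concentration tested, a lower number less inhibition of growth), three compounds sharing one core have been measured. Compound 1 `N#C/C(=C\c1ccccc1OS(=O)(=O)c1ccc(Cl)cc1)C(=O)Nc1nnc(Cc2cccc3ccccc23)s1` with naphthalen-1-yl gives 68% in this test. Compound 2 `N#C/C(=C\c1ccccc1OS(=O)(=O)c1ccc(Cl)cc1)C(=O)Nc1nnc(Cc2ccccc2)s1` with phenyl gives 73% in the same test. Compound 3 `N#C/C(=C\c1ccccc1OS(=O)(=O)c1ccc(Cl)cc1)C(=O)Nc1nnc(Cc2ccc(F)cc2)s1` with 4-fluorophenyl gives 68% and so stands level with compound 1 at the digits shown and within the scatter of compound 2. The steps among them are small: swapping naphthalen-1-yl for phenyl gives a number 5 percentage points higher from compound 1 to compound 2 (within the scatter) and swapping it for 4-fluorophenyl gives no change at the digits printed from compound 1 to compound 3 (within the scatter) while fluoro in place of hydrogen on an aromatic carbon gives a number 5 percentage points lower from compound 2 to compound 3 (within the scatter) as its result.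

Compound 4 `N#C/C(=C\c1ccccc1OS(=O)(=O)c1ccc(Cl)cc1)C(=O)Nc1nnc(-c2cccc(F)c2)s1` brings a different kind of change: 3-fluorophenyl in place of 4-fluorobenzyl on an aromatic carbon with 3-fluorophenyl in place of 4-fluorobenzyl on an aromatic carbon of the five-membered aromatic ring with 2 nitrogen and 1 sulfur. For the measured compounds named here, none of the measured steps makes this swap, so they bear on it only indirectly. Starting from compound 3 at 68% and with steps of that small size around it, no step beyond the scatter is expected in this assay here. The estimated change is a number 4 percentage points lower from compound 3 to compound 4 (within the scatter) and the untried kind of swap keeps the range wide. Compound 4 is estimated at 64% with an expected range from 45% to 80% in this test.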

Compound 4, percent growth inhibition at one concentration: 71%
For compound 4 the middle estimate is 7 percentage points below the measured one; low and high end bracket the measured number.
By their numbers in this assay, from the lowest: compounds 1, 3, 4 and 2 (each within the scatter of the next).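

In this assay, for the compounds shown here, the earlier compounds varied only the aromatic group on a saturated chain carbon, whereas 3-fluorophenyl in place of 4-fluorobenzyl takes that chain carbon away and gives a number 3 percentage points higher from compound 3 to compound 4 (within the scatter) as its result. The picture is the same against the other two compounds: 3-fluorophenyl in place of benzyl gives a number 2 percentage points lower from compound 2 to compound 4 (within the scatter) as its result, and 3-fluorophenyl in place of (naphthalen-1-yl)methyl gives a number 3 percentage points higher from compound 1 to compound 4 (within the scatter) as its result, so at this position the read-out does not separate an aromatic ring held on a chain carbon from one bound straight to the aromatic carbon of the five-membered ring. Nothing measured alongside these numbers accounts for this result.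

This swap also moves the fluorine on the ring, so the compounds shown cannot split the loss of the chain carbon from the new fluorine place, and a single tested concentration says nothing about how the compounds would compare at lower doses. Every group shown here carries an aromatic ring of carbon only, so the effect of an amine, a carboxylic acid or a longer chain such as 2-phenylethyl at this position stays open.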